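Ethyl for Phenyl on the Triazole Nitrogen of an Oxime Ether

A few compounds are considered here, and "the series" means these few. Any claim that something is new, unique, unknown or untested is made for them only; others in the source may bear on it.

Measured compounds:
compound 1, `COc1ccc(-c2nnc(SC/C(=N/O)c3ccccc3)n2-c2ccccc2)cc1`, 80%
compound 2, `O/N=C(/CSc1nnc(-c2ccccc2)n1-c1ccccc1)c1ccccc1`, 79%
compound 3, `O=C(CSc1nnc(-c2ccccc2)n1-c1ccccc1)c1ccccc1`, 68%

In a functional assay on the whole organism (strain albino) for inhibition, with Rattus norvegicus as the target, read by paw edema, with a stated time of 4 h, at a dose of 0.28 mmol/kg by the oral route (a higher number here means more inhibition at the dose given (going by the name of the read-out), a lower number less inhibition), compound 2 gives 79%, the second highest of the three numbers. Its nearest neighbour is compound 1, with a number 1 percentage points lower from compound 1 to compound 2 (within the scatter), so the two cannot be told apart. Its furthest is compound 3, with a number 11 percentage points lower from compound 2 to compound 3 (beyond the scatter), a modest but real loss.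

Compound 4 is `CCn1c(SC/C(=N/O)c2ccccc2)nnc1-c1ccccc1`. It differs from compound 2 in one place: ethyl in place of phenyl on an aromatic nitrogen.

Neither measured step touches this position. The change from compound 1 to compound 2 alters a substituent on a distant aromatic ring and leaves the read-out unchanged; the change from compound 2 to compound 3 alters the chain bound to sulfur. Nothing shown tells how the group on the ring nitrogen matters, so the size of the step in this assay is open, though a loss of the phenyl is taken as more likely to cost than to gain. Compound 4 is therefore expected to give about 65%, in a range from 45% to 80%. That estimate means an expected step of a number 14 percentage points lower from compound 2 to compound 4 (beyond the scatter).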

Compound 4, a percentage reported as inhibition, in the whole organism at one dose (the size of the read-out at that dose, not a potency): 73%
For compound 4 the middle estimate is 8 percentage points below the measured one; measured number inside the range.
By their numbers in this assay, from the lowest: compounds 3, 4, 2 and 1 (each within the scatter of the next, the first and the last beyond it).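

Among these compounds, at the aromatic nitrogen of the shared core, ethyl in place of phenyl gives a number 6 percentage points lower from compound 2 to compound 4 (within the scatter) in this assay, the first reading at this position. In this one pair, the phenyl group on that nitrogen is therefore not needed to keep the inhibition at the dose given, and a two-carbon ethyl group serves within the usual variation between repeats. Nothing available explains why the step is this small.

On these data alone, it remains open whether a longer chain such as butyl, a benzyl group or a chain ending in an amine would hold the inhibition on that nitrogen. As far as these compounds go, it is equally open whether ethyl would behave the same way alongside the methoxy group of compound 1 or the carbonyl of compound 3.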